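Replacing a Methyl by a Cyano Group on the Anilide

This account rests on a few compounds, and the source may have more. Where it says the series, first, only, none or still open, it means among the compounds named here.

Compound 1, `COC(=O)c1ccc(NC(=O)C2(C(=O)Nc3ccc(Nc4ncc5cc(C(=O)N(C)C)n(C6CCCC6)c5n4)cc3)CC2)cc1`, gives 77.1% in a functional assay on A549 cells (Homo sapiens) for inhibition, read by CCK-8 assay, with a stated time of 72 h, tested at 1 uM; a higher number here means more inhibition of growth at the concentration tested, a lower number less inhibition of growth.
Compound 2, `Cc1ccc(NC(=O)C2(C(=O)Nc3ccc(Nc4ncc5cc(C(=O)N(C)C)n(C6CCCC6)c5n4)cc3)CC2)cc1`, gives 40.2% in this assay.

Compound 2 stands lowest of the two numbers, separated from compound 1 by the step of a number 36.9 percentage points lower from compound 1 to compound 2 (beyond the scatter). Compound 3, `CN(C)C(=O)c1cc2cnc(Nc3ccc(NC(=O)C4(C(=O)Nc5ccc(C#N)cc5)CC4)cc3)nc2n1C1CCCC1`, differs from compound 2 in one place: cyano in place of methyl on an aromatic carbon. Only the measured step from compound 1 to compound 2 bears on this change; it was large and downward when methyl entered this position. Since compound 3 removes that methyl again, a smaller upward step is expected, estimated as a number 24.8 percentage points higher from compound 2 to compound 3 (beyond the scatter). Compound 3 is therefore estimated at 65%, within 45% to 82%.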

Compound 3, percent growth inhibition at one concentration: 86.1%
Beside the measured number, compound 3's estimate is 21.1 percentage points below it; the measured number lies above the stated range.
By their numbers in this assay, from the lowest: compound 2; then compounds 1 and 3 (each within the scatter of the next).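

The change to cyano gives a number 45.9 percentage points higher from compound 2 to compound 3 (beyond the scatter) in this assay, so the low number of compound 2 is not a general feature of this position on the ring. Cyano and methoxycarbonyl, though different groups, give values that cannot be told apart, with a number 9 percentage points higher from compound 1 to compound 3 (within the scatter), and among these three groups only methyl stands apart. Nothing available explains this difference. Going by these compounds, it remains open whether an amine, a carboxylic acid or a longer chain here would match cyano and methoxycarbonyl or fall towards methyl.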